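The source may hold more compounds than are shown below. What is called first, only, known or untested is meant among the compounds shown, and "the series" means these compounds.

In a functional assay on HepG2 cells (Homo sapiens) for antiproliferative activity, read by MTT assay, with a stated time of 72 h (on this read-out higher numbers stand for weaker inhibition and lower numbers for stronger inhibition), compound 1 `COc1cc2c(Nc3ccc(C#N)cc3)ncnc2cc1OCCCN1CCC(O)CC1` gives 67900 nM and compound 2 `CCOC(=O)C1CCN(CCCOc2cc3ncnc(Nc4ccc(C#N)cc4)c3cc2OC)CC1` gives 57700 nM. Compound 3 `COc1cc2c(Nc3cccc(C#N)c3)ncnc2cc1OCCCN1CCCC1` has the lowest number of the three, at 18200 nM, clearly apart from both others. The next compound, compound 4 `CCN1CCN(CCCOc2cc3ncnc(Nc4cccc(C#N)c4)c3cc2OC)CC1`, has not been measured and differs from compound 3 in one place: 4-ethylpiperazin-1-yl in place of pyrrolidin-1-yl on a saturated chain carbon, three bonds along the chain from an oxygen on an aromatic ring. Going by the values given here, only one measured step offers any guide, a 1.2-fold lower number from compound 1 to compound 2 (0.07 log units; within the scatter). That is a different swap on a different parent, so it is weak evidence, but it gives no reason to expect a shift beyond the scatter in this assay. The expected change is small, a 1.4-fold higher number from compound 3 to compound 4 (0.14 log units; within the scatter). Compound 4 is estimated at 25000 nM, with an expected range of 8000 nM to 70000 nM.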

Compound 4, half-maximal inhibitory concentration: 13700 nM
Beside the measured number, compound 4's estimate is 1.8-fold (0.26 log units) above it; the measured number falls inside the stated range.
By their numbers in this assay, from the lowest: compounds 4 and 3 (each within the scatter of the next); then compounds 2 and 1 (each within the scatter of the next).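

On the saturated chain carbon, three bonds along the chain from an oxygen on an aromatic ring, swapping pyrrolidin-1-yl for 4-ethylpiperazin-1-yl gives a 1.3-fold lower number from compound 3 to compound 4 (0.12 log units; within the scatter) in this assay. So at this place, the six-membered ring with its second nitrogen and ethyl group reads much like the five-membered ring, and this is the first change of the whole ring among these compounds. Nothing available explains this result.

Still open, from the compounds shown here alone, is whether morpholin-4-yl or an open-chain amine such as dimethylamino would read the same here. Going by these compounds, the effect of a longer chain also remains open.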